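The source may report more compounds than this note shows. Statements on the series, on what has been measured and on what is new or still open speak of the compounds shown alone.

Compound 2, with the structure `Cc1c(OCCCCOc2ccc(F)c(C(=O)O)c2)ccc(C(=O)CC2CCCC2)c1O`, gives 81% in an assay on HEK293 cells for positive allosteric modulation of metabotropic glutamate receptor 2 (Rattus norvegicus), read by thallium flux, with a stated time of 2.5 min (on this read-out higher numbers stand for larger maximal responses and lower numbers for smaller maximal responses), and on the numbers at hand it stands highest of the two measured values. Among the compounds with values here, the nearest is compound 1, `CCC(=O)c1ccc(OCCCCOc2ccc(F)c(C(=O)O)c2)c(C)c1O`, which in this assay gives 66.6%; the one measured step, a number 14.4 percentage points higher from compound 1 to compound 2 (beyond the scatter), comes from putting cyclopentyl in place of methyl on a saturated chain carbon bound to a carbonyl carbon.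

Compound 3, `COC(=O)c1ccc(OCCCCOc2ccc(C(=O)CC3CCCC3)c(O)c2C)cc1`, is the next compound to be measured in this assay. It differs from compound 2 at the other end of the molecule: 4-(methoxycarbonyl)phenyl in place of 3-carboxy-4-fluorophenyl on an oxygen on a saturated carbon. Within the data shown here, neither measured step touches this part of the structure, so no measured step bears on the change, and the data give no ground for expecting a shift in one direction or the other. In such a case the expectation for compound 3 rests on the value of compound 2 alone, with a broad range to allow for the untested change, and the expected step is a number 9 percentage points lower from compound 2 to compound 3 (within the scatter). Compound 3 is therefore estimated to give 72% in this assay, within a range from 40% to 100%.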

Compound 3, largest response reached (reported as percent of maximum), in percent of the reference or control that the assay uses: 12.2%
Compound 3: middle estimate off by 59.8 percentage points, on the high side; the measured number lies below the stated range.
By their numbers in this assay, from the lowest: compound 3; then compound 1; then compound 2.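

Compared with a number 14.4 percentage points higher from compound 1 to compound 2 (beyond the scatter), the change on an oxygen on a saturated carbon has a much larger effect in this assay: 4-(methoxycarbonyl)phenyl in place of 3-carboxy-4-fluorophenyl gives a number 68.8 percentage points lower from compound 2 to compound 3 (beyond the scatter). Within the data shown here, this is the first sign that the response depends strongly on this end of the molecule, and not only on the group at the carbonyl end. Among these compounds, the single step, however, replaces the carboxy group, removes the fluorine and changes the count of hydrogen-bond donors and acceptors all at once, and no measurement at hand shows which of these differences accounts for the fall.

The compounds shown leave open whether the loss follows the methyl ester itself or the altered ring, a question that compound 2 with a methyl ester in place of its carboxylic acid, or compound 3 with a carboxylic acid in place of its methyl ester, would separate. They also leave open how a tetrazole or a primary amide at this place would compare with the carboxylic acid of compound 2.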